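Replacing the Sulfonyl Substituent: Compound 3 to Compound 4

A few compounds are considered here, and "the series" means these few. Any claim that something is new, unique, unknown or untested is made for them only; others in the source may bear on it.

Measured so far in a functional assay on DU-145 cells (Homo sapiens) for inhibition, read by trypan blue exclusion, with a stated time of 96 h; a higher number here means a weaker inhibitor of growth, a lower number a stronger inhibitor of growth:
Compound 1 `Cc1ccc(CS(=O)(=O)/C(=C/c2c[nH]c3ccccc23)C(=O)c2ccc(Cl)cc2)cc1` gives 25000 nM.
Compound 2 `CSc1ccc(/C=C(\C(=O)c2ccc(Cl)cc2)S(=O)(=O)Cc2ccc(C)cc2)cc1` gives 10000 nM.
Compound 3 `Cc1ccc(C)c(/C=C(\C(=O)c2ccc(Cl)cc2)S(=O)(=O)c2ccc(Br)cc2)c1` gives 1000 nM.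

Compound 3 has the lowest number of the three, so it is the strongest growth inhibitor here; compound 2 is nearest, and compound 1 furthest. Compound 4 `Cc1ccc(CS(=O)(=O)/C(=C/c2cc(C)ccc2C)C(=O)c2ccc(Cl)cc2)cc1` differs from compound 3 in one place: 4-methylbenzyl in place of 4-bromophenyl on a sulfonyl sulfur. Among the measured compounds shown here, the only measured step, a 2.5-fold lower number from compound 1 to compound 2 (0.40 log units; beyond the scatter), alters the group on the chain carbon, not the sulfonyl, so it does not bear directly on this change. Compounds 1 and 2 both carry 4-methylbenzyl on the sulfonyl and give weaker numbers than compound 3, but they differ from compound 3 elsewhere too. A modest weakening is therefore expected, a 4.0-fold higher number from compound 3 to compound 4 (0.60 log units; beyond the scatter), with compound 4 estimated at 4000 nM in a range of 1200 nM to 15000 nM.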

Compound 4, concentration for 50% growth inhibition: 1000 nM
Compound 4: middle estimate off by 4.0-fold (0.60 log units), on the high side, outside the stated range (below it).
By their numbers in this assay, from the lowest: compounds 3 and 4 (each within the scatter of the next); then compound 2; then compound 1.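

At this sulfonyl sulfur, 4-methylbenzyl can stand in place of 4-bromophenyl in this assay with no change at the digits printed from compound 3 to compound 4 (within the scatter), so 4-methylbenzyl alone does not account for the weaker numbers of compounds 1 and 2. With 4-methylbenzyl kept, 2,5-dimethylphenyl on the double-bonded chain carbon gives a 10-fold lower number from compound 2 to compound 4 (1.00 log units; beyond the scatter) and a 25-fold lower number from compound 1 to compound 4 (1.40 log units; beyond the scatter), placing the larger differences at that carbon. No supporting evidence explains these results. Still open, as far as these compounds go, is whether a methyl or an aminoethyl group on the sulfonyl sulfur would preserve this growth inhibition.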